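The source may report more compounds than this note shows. Statements on the series, on what has been measured and on what is new or still open speak of the compounds shown alone.

Three analogues of the shared core have been run in a functional assay on MCF7 cells (Homo sapiens) for inhibition, read by MTT assay, with a stated time of 48 h; on this read-out higher numbers stand for weaker inhibition and lower numbers for stronger inhibition. Compound 1 `CCOC(=O)C1=C(N/N=C(/Br)c2ccccc2)Nc2[nH]nc(C)c2C1c1ccc(N(C)C)cc1` gives 78400 nM; compound 2 `CCOC(=O)C1=C(N/C=N/c2ccccn2)Nc2[nH]nc(C)c2C1c1ccc(N(C)C)cc1` gives 37300 nM; compound 3 `CCOC(=O)C1=C(N/C=N/c2ccc([N+](=O)[O-])cc2)Nc2[nH]nc(C)c2C1c1ccc(N(C)C)cc1` gives 58600 nM. Compound 3 stands second highest of the three numbers, with compound 1 nearest and compound 2 furthest, both within the scatter of it. Going by the values given here, the only step beyond the scatter is a 2.1-fold lower number from compound 1 to compound 2 (0.32 log units; beyond the scatter), a modest one; a 1.3-fold lower number from compound 1 to compound 3 (0.13 log units; within the scatter) and a 1.6-fold higher number from compound 2 to compound 3 (0.20 log units; within the scatter) stay within the scatter, so swapping one group for another on that amine nitrogen has moved the number little.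

Compound 4 `CCOC(=O)C1=C(N)Nc2[nH]nc(C)c2C1c1ccc(N(C)C)cc1` has not yet been measured. Its difference from compound 3 is a hydrogen atom in place of a group of 11 heavy atoms (7 carbon, 2 nitrogen, 2 oxygen; one six-membered aromatic ring of carbon only), on an amine nitrogen. Among the compounds with values here, no measured step removes a group to leave bare hydrogen at this position, so the change is larger than any step seen, and direction cannot be read from the series. Given that the three measured values all lie close together, compound 4 is expected to fall near them, and the step of a 1.2-fold higher number from compound 3 to compound 4 (0.08 log units; within the scatter) is estimated to stay roughly within the scatter. The estimate for compound 4 in this assay is 70000 nM, with a range from 25000 nM to 200000 nM.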

Compound 4, half-maximal inhibitory concentration: 5060 nM
The estimate for compound 4 lay 14-fold (1.14 log units) above the measured number; the measured number lies below the stated range.
By their numbers in this assay, from the lowest: compound 4; then compounds 2, 3 and 1 (each within the scatter of the next, the first and the last beyond it).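

In this assay the amine nitrogen on the double-bonded ring carbon turns out to be a sensitive position: with hydrogen in place of the whole group, the series shows a 12-fold lower number from compound 3 to compound 4 (1.06 log units; beyond the scatter) and a 7.4-fold lower number from compound 2 to compound 4 (0.87 log units; beyond the scatter) and also a 15-fold lower number from compound 1 to compound 4 (1.19 log units; beyond the scatter) in the same direction. The earlier steps only exchanged one aromatic-ring group for another, whereas removing the group moves the number far more, whichever of the three groups leaves, and none of the compounds shown goes against this. Nothing at hand bears on why the number falls once the group is gone.

The compounds shown do not tell whether bare hydrogen is required or whether a small group such as methyl or acetyl on this nitrogen would keep the lower number. Nor do they show how a chain of intermediate length, such as ethyl or n-butyl, would compare.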